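Sulfur-linked substituent series: benzimidazolylmethyl to halobenzyl

The source may report more compounds than this note shows. Statements on the series, on what has been measured and on what is new or still open speak of the compounds shown alone.

The compounds share one core and differ only in the group on the saturated chain carbon bound to the sulfur. Compound 1 `Cc1cc(N2CC[C@@H](C)[C@@H](N(C)c3ncnc4[nH]ccc34)C2)n2nc(SCC3CCCCC3)nc2n1` carries a cyclohexyl there; in a functional assay on HGC-27 cells (Homo sapiens) for inhibition, read by MTT assay, with a stated time of 72 h (a lower number here means a stronger inhibitor, a higher number a weaker inhibitor), compound 1 gives 11500 nM. Compound 2 `C=CCSc1nc2nc(C)cc(N3CC[C@@H](C)[C@@H](N(C)c4ncnc5[nH]ccc45)C3)n2n1` carries a vinyl; in this assay compound 2 gives 35200 nM, the step being a 3.1-fold higher number from compound 1 to compound 2 (0.49 log units; beyond the scatter). Compound 3 `Cc1cc(N2CC[C@@H](C)[C@@H](N(C)c3ncnc4[nH]ccc34)C2)n2nc(SCc3nc4ccccc4[nH]3)nc2n1` carries a 1H-benzimidazol-2-yl. For compound 3 this assay reports only a limit, > 100000 nM. Compound 3 thus sits at the weak end of the three measured compounds, with an at least 8.6-fold higher number from compound 1 to compound 3 (0.93 log units; beyond the scatter) and an at least 2.8-fold higher number from compound 2 to compound 3 (0.45 log units; beyond the scatter) both running toward higher numbers; because of the limit of > 100000 nM in this assay, at which 1 of the 3 values shown sits, the full size of these two steps is not known.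

Compound 4 `Cc1cc(N2CC[C@@H](C)[C@@H](N(C)c3ncnc4[nH]ccc34)C2)n2nc(SCc3ccc(F)c(Cl)c3)nc2n1` differs from compound 3 in one place: 3-chloro-4-fluorophenyl in place of 1H-benzimidazol-2-yl on a saturated chain carbon bound to a sulfur. Within the data shown here, the group that leaves is the one that raised the number in both measured steps onto compound 3; the group that enters is an aromatic ring of carbon only, which stands nearer to the cyclohexyl of compound 1 and the vinyl of compound 2 than to the group it replaces. A step back toward lower numbers, at least modest in size, is therefore expected. Compound 4 is estimated at 25000 nM, within 8000 nM to 90000 nM, which means an expected step of an at least 4.0-fold lower number from compound 3 to compound 4 (0.60 log units; beyond the scatter).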

Compound 4, half-maximal inhibitory concentration: > 100000 nM
Compound 4: a limit, no number (the forecaster's own chance of this, stated with the estimate: 20%); middle value at least 4.0-fold (0.60 log units) away from the limit.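

Compound 4, with 3-chloro-4-fluorophenyl on the saturated chain carbon bound to the sulfur, also gives only a limit in this assay, the same limit as compound 3: the limit of > 100000 nM in this assay, at which 2 of the 4 values shown sit.

The step between these two compounds cannot be read, while the readable steps are an at least 2.8-fold higher number from compound 2 to compound 4 (0.45 log units; beyond the scatter) and an at least 8.6-fold higher number from compound 1 to compound 4 (0.93 log units; beyond the scatter). Removing the hetero atoms and the hydrogen-bond donor of 1H-benzimidazol-2-yl thus gives no measurable return toward compound 1 or compound 2, and both aromatic groups shown at this position stay unresolved at the limit, whereas cyclohexyl and vinyl give numbers.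

On these data alone, how far compound 3 and compound 4 actually lie apart remains open. Also open, as far as these compounds go, is where an unsubstituted phenyl, a longer alkyl chain or a chain ending in an amine would fall.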